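The compounds below may be only part of what the source reports. "The series", "measured", "known", "first", "only" and "open" are said of these compounds alone.

The series shares one core. Compound 1 `C[C@H](Nc1ncnc2[nH]cnc12)c1cc2ccc(F)cn2c(=O)c1-c1ccccc1` gives 94% in an ADME assay on microsomes from liver (Mus musculus), read by LC-MS, using NADPH, with a stated time of 30 min, tested at 1 uM; on this read-out lower numbers stand for a less stable compound and higher numbers for a more stable compound. Compound 2 `C[C@H](Nc1nc(N)nc(N)c1C#N)c1cc2ccc(F)cn2c(=O)c1-c1ccccc1` gives 42% in this assay, and compound 3 `C[C@H](Nc1nc(N)ncc1C#N)c1cc2ccc(F)cn2c(=O)c1-c1ccccc1` gives 11%. Compound 2 stands second highest of the three numbers: the step of a number 52 percentage points lower from compound 1 to compound 2 (beyond the scatter) lies beyond the scatter, as does the step of a number 31 percentage points lower from compound 2 to compound 3 (beyond the scatter), and the step of a number 83 percentage points lower from compound 1 to compound 3 (beyond the scatter) is the largest of all.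

Compound 4 `Cc1cccc(-c2c([C@H](C)Nc3nc(N)nc(N)c3C#N)cc3ccc(F)cn3c2=O)c1` differs from compound 2 by methyl in place of hydrogen on an aromatic carbon. None of the three measured steps touches the six-membered aromatic ring of carbon only: each of them alters the group attached to the amine nitrogen, while the ring that carries the new methyl is the same in compound 1, compound 2 and compound 3. Among the measured compounds shown here, there is no measured step that bears directly on this change, and the data give no ground for a large move in either direction. The expected step in this assay from compound 2 to compound 4 is one within the usual scatter, a number 4 percentage points lower from compound 2 to compound 4 (within the scatter). The estimate for compound 4 in this assay is 38%, with a range from 15% to 60%.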

Compound 4, percent of the compound remaining: < 1%
Compound 4 was reported as a limit; the forecaster's own chance of this, stated with the estimate: 0%; middle value at least 37 percentage points from the limit.
By their numbers in this assay, from the lowest: compound 3; then compound 2; then compound 1. At a limit, below all of these: compound 4.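

Until now the phenyl on the shared core had stayed the same in compound 1, compound 2 and compound 3, so the steps in this assay spoke only of the group on the amine nitrogen. The change from phenyl to 3-methylphenyl now shows that this ring is no silent place, since the single methyl, on an aromatic carbon meta to a large group, brings a number at least 41 percentage points lower from compound 2 to compound 4 (beyond the scatter), a large step of the same class as a number 31 percentage points lower from compound 2 to compound 3 (beyond the scatter), which arose on the other side of the molecule. Compound 4 is reported only as a limit of the assay, so the true size of its step stays unfixed and only its lower bound is known: the limit of < 1% in this assay, at which 1 of the 4 values shown sits.

The compounds shown leave open whether this drop belongs to the methyl itself, or whether a fluorine, a chlorine or a methoxy group on the same aromatic carbon would bring a step of similar size. They also leave open whether the same methyl would have a like effect with the group on the amine nitrogen of compound 1, and they do not tell which part of compound 4 is lost in the assay.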